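The compounds below may be only part of what the source reports. "The series", "measured", "known", "first", "only" and "open" are said of these compounds alone.

Working notes on the series in a toxicity assay on NIH3T3 cells (Mus musculus) for cytotoxicity, read by resazurin assay; a lower number here means that less compound is needed, a higher number that more compound is needed for the effect. Compound 1 `COC(=O)c1ccc(NCc2cncn2Cc2cccc(Br)c2)cc1-c1ccccc1` reads > 10000 nM, which is a limit and not a number. Compound 2 `Nc1cc(-c2ccccc2)ccc1Cn1cncc1CNc1ccc(Cl)c(-c2ccccc2)c1` reads > 1000 nM, also a limit. Compound 3 `Cc1cccc(-c2cccc(NCc3cncn3Cc3ccccc3)c2)c1C` reads > 1000 nM, again a limit. For the measured compounds named here, compound 1 therefore stands with a limit only, and so far the series holds no measured number and no measured step.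

Compound 4 `COC(=O)c1ccc(NCc2cncn2Cc2ccccc2Cl)cc1-c1ccccc1` keeps the core of compound 1 and changes one group: 2-chlorophenyl in place of 3-bromophenyl on a saturated chain carbon bound to an aromatic nitrogen. No step beyond the scatter is expected in this assay, in either direction. The estimated step runs a number no higher from compound 1 to compound 4 (the limit leaves the size open). That expectation rests on compound 1, whose limit is > 10000 nM. For compound 4 the estimated value is 10000 nM, with an expected range from 3000 nM to 30000 nM.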

Compound 4, half-maximal effective concentration: 10000 nM
For compound 4 middle estimate and measured number coincide at the digits printed; the measured number falls inside the stated range.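

In this assay, for the compounds shown here, compound 4 gives the first actual number, 10000 nM, so a change on a saturated chain carbon bound to an aromatic nitrogen now ends in a measured reading. 2-chlorophenyl in place of 3-bromophenyl runs a number no higher from compound 1 to compound 4 (the limit leaves the size open). Compound 1 holds a limit and not a number: the limit of > 10000 nM in this assay, at which 1 of the 4 values shown sits.

As far as these compounds go, this change alters both the halogen and its place on the ring, and what 3-chlorophenyl would read at this position stays open. Also open, from the compounds shown here alone, is how an aminophenyl or a carboxyphenyl group would read there.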